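Phenyl Replaces Ethyl on a Ring Amide Nitrogen

The source may report more compounds than this note shows. Statements on the series, on what has been measured and on what is new or still open speak of the compounds shown alone.

Compound 1 `O=C1c2cc(C3CC3)nc(Oc3cccc(NS(=O)(=O)c4ccc(Cl)cc4)c3)c2C(=O)N1C1CC1`: 99%
Compound 2 `CCN1C(=O)c2cc(C)nc(Oc3cccc(NS(=O)(=O)c4ccc(Cl)cc4)c3)c2C1=O`: 120%

In a functional assay on HEK293 cells for agonist activity at Glucose-dependent insulinotropic receptor (Homo sapiens), read by cAMP accumulation, with a stated time of 30 min (a higher number here means a larger maximal response, a lower number a smaller maximal response), compound 1 gives 99%, while compound 2 gives 120%, the higher of the two numbers, with a gap to compound 1 that lies beyond the usual scatter. Compound 3 `Cc1cc2c(c(Oc3cccc(NS(=O)(=O)c4ccc(Cl)cc4)c3)n1)C(=O)N(c1ccccc1)C2=O` is not yet measured. It differs from compound 2 in one place: phenyl in place of ethyl on an amide-type nitrogen in a ring. Going by the values given here, no measured pair shows what a change at this position does, so no direction can be drawn from the data. The step of a number 12 percentage points lower from compound 2 to compound 3 (beyond the scatter) is expected to be small, probably within the scatter, leaning slightly downward. For compound 3 the estimated efficacy is 108%, with a range from 85% to 130%.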

Compound 3, largest response reached (reported as efficacy), in percent of the reference or control that the assay uses: 102%
Beside the measured number, compound 3's estimate is 6 percentage points above it; low and high end bracket the measured number.
By their numbers in this assay, from the lowest: compounds 1 and 3 (each within the scatter of the next); then compound 2.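

In this assay, phenyl in place of ethyl on the amide-type nitrogen gives a number 18 percentage points lower from compound 2 to compound 3 (beyond the scatter) and is a modest loss. Going by these compounds alone, this is the first measured change at this position, showing that its group can alter the maximal response, although compound 3 still gives 102%. No available evidence explains the drop. Open, from the compounds shown here alone, is whether a longer chain such as propyl would behave more like ethyl or phenyl. A benzyl group could also help separate the effect of group size from that of having an aromatic ring.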